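This account rests on a few compounds, and the source may have more. Where it says the series, first, only, none or still open, it means among the compounds named here.

Measured so far in a functional assay on MGC-803 cells (Homo sapiens) for antiproliferative activity, read by MTT assay, with a stated time of 48 h; on this read-out higher numbers stand for weaker inhibition and lower numbers for stronger inhibition:
compound 1 `Cc1ccc(NC(=O)Nc2cccc(CNc3nccnc3Cl)c2)cc1C` gives 9870 nM
compound 2 `O=C(Nc1cccc(CNc2nccnc2Cl)c1)Nc1ccccc1Cl` gives 7130 nM
compound 3 `CCOc1ccc(NC(=O)Nc2cccc(CNc3nccnc3Cl)c2)cc1` gives 7240 nM

Compound 3 holds the second highest of the three numbers; its neighbours lie close, as a 1.0-fold higher number from compound 2 to compound 3 (0.01 log units; within the scatter) and a 1.4-fold lower number from compound 1 to compound 3 (0.13 log units; within the scatter) show, both within the scatter.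

Compound 4 `CC(C)(C)c1ccc(NC(=O)Nc2cccc(CNc3nccnc3Cl)c2)cc1` is next. Its change from compound 3: tert-butyl in place of ethoxy on an aromatic carbon, on an aromatic carbon of a six-membered aromatic ring of carbon only, para to a large group. Within the data shown here, the steps that bear on it are those that swapped the aryl group on the amide-type nitrogen: a 1.4-fold lower number from compound 1 to compound 2 (0.14 log units; within the scatter), a 1.4-fold lower number from compound 1 to compound 3 (0.13 log units; within the scatter) and a 1.0-fold higher number from compound 2 to compound 3 (0.01 log units; within the scatter), all within the scatter. Nothing in the series points to a step beyond the scatter in this assay for such a swap, so the expected step is a 1.0-fold higher number from compound 3 to compound 4 (0.02 log units; within the scatter). Compound 4 is therefore estimated at 7500 nM, in the range 3500 nM to 16000 nM.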

Compound 4, half-maximal inhibitory concentration: 4820 nM
The estimate for compound 4 lay 1.6-fold (0.19 log units) above the measured number; measured number inside the range.
By their numbers in this assay, from the lowest: compounds 4, 2, 3 and 1 (each within the scatter of the next, the first and the last beyond it).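

In this assay, tert-butyl in place of ethoxy on an aromatic carbon, para to a large group, gives a 1.5-fold lower number from compound 3 to compound 4 (0.18 log units; within the scatter). This position therefore tolerates the loss of the ethoxy hydrogen-bond acceptor and an all-carbon group in its place, with the step staying within the scatter. No measurement available here accounts for this step.

Open, from the compounds shown here alone, is whether an amine or a carboxylic acid at this position would give a step beyond the scatter. Also open, going by these compounds, is whether a longer chain there would do so.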